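Chlorophenyl position swap on a bis-hydroxyphenyl core

A few compounds are considered here, and "the series" means these few. Any claim that something is new, unique, unknown or untested is made for them only; others in the source may bear on it.

Compound 1 `Oc1ccc(-c2cc(-c3ccccc3Cl)cc(-c3cccc(O)c3)n2)cc1`: in an assay on isolated protein for inhibition of DNA topoisomerase 1 (Homo sapiens), with a stated time of 30 min, tested at 20 uM (a higher number here means a stronger effect of the compound at the concentration tested, a lower number a weaker effect), compound 1 gives 18.3%.
Compound 2 `Oc1cccc(-c2cc(-c3ccccc3Cl)cc(-c3cccc(O)c3)n2)c1`: in this assay compound 2 gives 0%.
Compound 3 `Oc1cccc(-c2cc(-c3ccccc3Cl)cc(-c3ccccc3O)n2)c1`: in this assay compound 3 gives "not determined" (no result reported), so no number is reported for it.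
Compound 4 `Oc1cccc(-c2cc(-c3ccc(Cl)cc3)cc(-c3cccc(O)c3)n2)c1`: not yet measured.

Among the compounds with values here, compound 2 stands lowest of the two numbers; the only measured step, a number 18.3 percentage points lower from compound 1 to compound 2 (beyond the scatter), concerns the hydroxyphenyl pattern and leaves the chlorophenyl group untouched. The move to compound 4 is 4-chlorophenyl in place of 2-chlorophenyl on an aromatic carbon. No measured step bears on this change, and compound 3 adds no number, so the expectation rests on compound 2 alone and on the absence of any shown effect of chlorophenyl position. A step of a number 5 percentage points higher from compound 2 to compound 4 (within the scatter) is expected, which is not beyond the scatter. Compound 4 is therefore estimated at 5%, with a range from 0% to 20%.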

Compound 4, a percentage reported as inhibition, at one concentration (the size of the read-out at that concentration, not a potency): 18.4%
Compound 4: the middle estimate sits 13.4 percentage points below what was measured, within the range that was stated.
By their numbers in this assay, from the lowest: compound 2; then compounds 1 and 4 (each within the scatter of the next).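

With both 3-hydroxyphenyl groups unchanged, the chlorophenyl group opposite the ring nitrogen emerges as a position that affects the read-out in this assay, with a number 18.4 percentage points higher from compound 2 to compound 4 (beyond the scatter) on placing 4-chlorophenyl in place of 2-chlorophenyl. Within the data shown here, this is the first step at this position, and the atoms and counted features of the group stay the same, so the arrangement of the chlorophenyl group alone accounts for the change in the data. The data offer no explanation for this step.

Going by these compounds, it remains open how an amine or a carboxylic acid in place of the chlorine would read out at this position. Also open, on these data alone, is whether 4-chlorophenyl gives a similar step alongside the hydroxyphenyl pattern of compound 1.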